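The source may report more compounds than this note shows. Statements on the series, on what has been measured and on what is new or still open speak of the compounds shown alone.

Compound 1 `Nc1nc(=O)ccn1[C@@H]1O[C@H](COP(=O)(O)OP(=O)(O)O)[C@@H](O)[C@H]1O` is a nucleotide whose pyrimidine-like core carries an amino group and a diphosphate chain on the sugar. In an in vitro functional assay on 1321-N1 cells for agonist activity at P2Y purinoceptor 6 (Homo sapiens), read by scintillation proximity assay and inositol phosphate accumulation (a lower number here means that less compound is needed, a higher number that more compound is needed for the effect), compound 1 gives >= 100000 nM, which is a limit of the assay rather than a measured number. Compound 2 `O=c1[nH]c(=S)ccn1[C@@H]1O[C@H](COP(=O)(O)O)[C@@H](O)[C@H]1O` is a related nucleotide with a single phosphate and a thiocarbonyl on the core; in this assay compound 2 gives > 100000 nM, again only a limit. Both values therefore sit at the edge of what the assay can report, and neither stands apart from the other. Compound 3 `CSc1nc(=O)ccn1[C@@H]1O[C@H](COP(=O)(O)OP(=O)(O)O)[C@@H](O)[C@H]1O` differs from compound 1 in one place: methylsulfanyl in place of amino on an aromatic carbon. Among the measured compounds shown here, with no measured step to lean on, the direction of the change from compound 1 to compound 3 is open; the expected step is an at least 3.3-fold lower number from compound 1 to compound 3 (0.52 log units; beyond the scatter). In this assay compound 3 is estimated at 30000 nM, within a range from 3000 nM to 150000 nM.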

Compound 3, half-maximal effective concentration: 4700 nM
Beside the measured number, compound 3's estimate is 6.4-fold (0.81 log units) above it, within the range that was stated.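

Among the compounds shown here, compound 3 is the first compound here to give a real number in this assay, so this position, on an aromatic carbon between two ring nitrogen atoms, can carry a change that moves the read-out. With the diphosphate chain and the rest of the structure unchanged, putting methylsulfanyl in place of amino gives an at least 21-fold lower number from compound 1 to compound 3 (1.32 log units; beyond the scatter). That size is only a minimum, since compound 1 has no exact value to start from: the limit of >= 100000 nM in this assay, at which 1 of the 3 values shown sits.

The compounds shown leave open whether the sulfur, the methyl or the loss of the amino group matters most, and how a methoxy group or a longer chain such as ethylsulfanyl would fare at the same place. For the compounds shown here, compound 2 differs from the others in more than one place, so no step to it can be read.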